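Swapping a Methoxy Group for Chlorine at the Amide Carbonyl

This account rests on a few compounds, and the source may have more. Where it says the series, first, only, none or still open, it means among the compounds named here.

In an ADME assay on HepG2 2.2.15 cells (Homo sapiens) for cytotoxicity, read by CCK-8 assay, with a stated time of 8 days (a lower number here means that less compound is tolerated, a higher number that more compound is tolerated), compound 3 `CCOc1ccc(-c2cc(NC(=O)c3cc(OC)ccc3O)c[nH]c2=O)cc1` gives 57700 nM. That number lies within the scatter of both neighbouring values, from compound 2 `CCOc1ccc(-c2cc(NC(=O)c3ccc(OC)cc3O)c[nH]c2=O)cc1` at 69600 nM and compound 1 `Cc1cccc(-c2cc(NC(=O)c3ccc(Cl)cc3O)c[nH]c2=O)c1` at 33100 nM.

Compound 4 `CCOc1ccc(-c2cc(NC(=O)c3ccc(Cl)cc3O)c[nH]c2=O)cc1` differs from compound 3 at one place, on a carbonyl carbon whose other neighbour is an amide-type nitrogen: 4-chloro-2-hydroxyphenyl stands in place of 2-hydroxy-5-methoxyphenyl (4-chloro-2-hydroxyphenyl in place of 2-hydroxy-5-methoxyphenyl on a carbonyl carbon). Going by the values given here, the only measured step at this place is a 1.2-fold lower number from compound 2 to compound 3 (0.08 log units; within the scatter). It stays within the scatter, but it exchanges one methoxy-bearing group for another, so it does not show what the chlorine-bearing group does. The closest guide is compound 1, which carries the same 4-chloro-2-hydroxyphenyl group on a different remainder and gives 33100 nM. No change beyond the scatter is therefore expected, and the estimated step is a 1.3-fold lower number from compound 3 to compound 4 (0.11 log units; within the scatter). The expected value for compound 4 is 45000 nM, with an estimated range of 22000 nM to 85000 nM.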

Compound 4, half-maximal cytotoxic concentration: 28600 nM
Beside the measured number, compound 4's estimate is 1.6-fold (0.20 log units) above it; measured number inside the range.
By their numbers in this assay, from the lowest: compounds 4, 1, 3 and 2 (each within the scatter of the next, the first and the last beyond it).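

Going by these compounds alone, with the 4-chloro-2-hydroxyphenyl group now measured on the same remainder as the methoxy compounds, this assay shows a 2.0-fold lower number from compound 3 to compound 4 (0.30 log units; within the scatter) and, for chloro in place of methoxy on an aromatic carbon, a 2.4-fold lower number from compound 2 to compound 4 (0.39 log units; beyond the scatter) as the first step at this place to pass the scatter, though only modestly. A lower number here means that less compound is tolerated, so chloro goes with less tolerance than the methoxy group of compound 2, while the comparison with compound 3 stays within the scatter. The change elsewhere in the molecule, a 1.2-fold lower number from compound 1 to compound 4 (0.06 log units; within the scatter) with 4-ethoxyphenyl in place of 3-methylphenyl, does not separate those two groups when this chlorine-bearing group is present.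

As far as these compounds go, how an amine or a carboxylic acid in place of the chloro would read remains open. Nothing measured here explains the step seen with chloro.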